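Methyl on the pyrrole nitrogen: compound 2 to compound 4

This account rests on a few compounds, and the source may have more. Where it says the series, first, only, none or still open, it means among the compounds named here.

Compound 2 `Cc1occc1-c1nnc2n1NC(c1ccc[nH]1)S2` gives 13.7% in a functional assay on the whole organism (strain Wistar Albino) for inhibition, with Rattus norvegicus as the target, read by paw edema, with a stated time of 1 h, at a dose of 20 mg/kg; on this read-out higher numbers stand for more inhibition at the one dose given (going by the name of the read-out) and lower numbers for less inhibition. This number lies together with those of compound 1 `Cc1occc1-c1nnc2n1NC(c1ccco1)S2`, which gives 16.4%, and of compound 3 `COc1ccc(Cl)c(-c2nnc3n2NC(c2cccn2C)S3)c1`, which gives 14.1%; the three fall within the usual scatter of one another. Compound 4 `Cc1occc1-c1nnc2n1NC(c1cccn1C)S2` differs from compound 2 by methyl in place of hydrogen on an aromatic nitrogen. For the measured compounds named here, the only measured step, from compound 1 to compound 2, changed the same group: a number 2.7 percentage points lower from compound 1 to compound 2 (within the scatter). Compound 3 carries the same 1-methyl-1H-pyrrol-2-yl group on a different core, and its value shows nothing different from the others. Going by the values given here, no measured step exceeds the scatter, so no step beyond it is expected here; the estimated step is a number 0.8 percentage points higher from compound 2 to compound 4 (within the scatter). For compound 4 the expected value is 14.5%, with a range from 7% to 23%.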

Compound 4, a percentage reported as inhibition, in the whole organism at one dose (the size of the read-out at that dose, not a potency): 14.6%
The estimate for compound 4 lay 0.1 percentage points below the measured number; measured number inside the range.
By their numbers in this assay, from the lowest: compounds 2, 3, 4 and 1 (each within the scatter of the next).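

In this assay, methyl on the aromatic nitrogen gives a number 0.9 percentage points higher from compound 2 to compound 4 (within the scatter), so this hydrogen can be replaced without a shift that stands out from the scatter. Changing furan-2-yl to 1-methyl-1H-pyrrol-2-yl gives a number 1.8 percentage points lower from compound 1 to compound 4 (within the scatter), so the three groups at this position on the shared core cannot be told apart here. No evidence at hand explains this result. The compounds shown leave open whether a longer chain, or a chain ending in an amine or a carboxylic acid, on this nitrogen would move the number beyond the scatter.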